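From 4-chlorophenyl to pyridin-3-yl on the shared core

The compounds below may be only part of what the source reports. "The series", "measured", "known", "first", "only" and "open" are said of these compounds alone.

In a functional assay on MIA PaCa-2 cells (Homo sapiens) for inhibition, read by MTT assay (on this read-out higher numbers stand for weaker inhibition and lower numbers for stronger inhibition), compound 1 `CN(C)C(=O)c1cc2cnc(NC3CCCCC3)nc2n1C1CCCC1` gives 25000 nM, compound 2 `CN(C)C(=O)c1cc2cnc(Nc3ccccc3)nc2n1C1CCCC1` gives 54900 nM and compound 3 `CN(C)C(=O)c1cc2cnc(Nc3ccc(Cl)cc3)nc2n1C1CCCC1` gives 13000 nM. Compound 3 shares the low end of these numbers with compound 1, the step between them being a 1.9-fold lower number from compound 1 to compound 3 (0.28 log units; within the scatter), while compound 2 stands apart at the high end.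

Compound 4 `CN(C)C(=O)c1cc2cnc(Nc3cccnc3)nc2n1C1CCCC1` carries pyridin-3-yl in place of 4-chlorophenyl on a nitrogen on an aromatic ring. The closest measured evidence is a 4.2-fold lower number from compound 2 to compound 3 (0.63 log units; beyond the scatter), a chloro in place of hydrogen, and compound 4 has no chloro. The step of a 2.2-fold higher number from compound 1 to compound 2 (0.34 log units; beyond the scatter) shows where an unsubstituted phenyl stands. Among the measured compounds shown here, no measured compound carries a ring with a hetero atom, so that part of the change remains untested. A modest move to a higher number in this assay is therefore expected, and the estimated step is a 2.9-fold higher number from compound 3 to compound 4 (0.47 log units; beyond the scatter). Compound 4 is expected at 38000 nM, with an estimated range of 14000 nM to 100000 nM.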

Compound 4, half-maximal inhibitory concentration: 26000 nM
Compound 4: middle estimate off by 1.5-fold (0.16 log units), on the high side; low and high end bracket the measured number.
By their numbers in this assay, from the lowest: compounds 3, 1 and 4 (each within the scatter of the next); then compound 2.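

In this assay, pyridin-3-yl, the first ring with a hetero atom on this nitrogen, cannot be told apart from 4-chlorophenyl (a 2.0-fold higher number from compound 3 to compound 4 (0.30 log units; within the scatter)) or from cyclohexyl (a 1.0-fold higher number from compound 1 to compound 4 (0.02 log units; within the scatter)). It does separate from phenyl (a 2.1-fold lower number from compound 2 to compound 4 (0.32 log units; beyond the scatter)), so among these four compounds chloro is no longer the only change from phenyl that gives a lower number, and compound 2 alone stands apart from the other three. No measurement to hand explains this result.

The compounds shown leave open whether the ring nitrogen must sit where it does in pyridin-3-yl, as pyridin-2-yl and pyridin-4-yl would show. They also do not say how a 4-methoxyphenyl or a 4-(piperazin-1-yl)phenyl group would compare on this nitrogen.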